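Phenyl for methoxy on the aryl group of compound 1

A few compounds are considered here, and "the series" means these few. Any claim that something is new, unique, unknown or untested is made for them only; others in the source may bear on it.

compound 1 `C=CC(=O)N1C(=O)CC(c2ccc(OC)cc2)Sc2ccccc21`: 43300 nM
compound 2 `C=CC(=O)N1C(=O)CCSc2ccccc21`: 581000 nM
compound 3 `C=CC(=O)N1C(=O)CC(c2ccc(-c3ccccc3)cc2)Sc2ccccc21`: not yet measured

In a functional assay on Raji cells (Homo sapiens) for cytotoxicity, read by CCK-8 assay, with a stated time of 24 h (on this read-out lower numbers stand for stronger inhibition and higher numbers for weaker inhibition), compound 1 holds the lower of the two numbers, 43300 nM. Compound 3 carries phenyl in place of methoxy on an aromatic carbon. Among the compounds with values here, the only measured step, a 13-fold higher number from compound 1 to compound 2 (1.13 log units; beyond the scatter), puts hydrogen in place of the whole 4-methoxyphenyl, so it bears only indirectly on this change. A much smaller step is therefore expected in this assay, leaning toward a lower number and probably within the scatter. The expected step is a 1.7-fold lower number from compound 1 to compound 3 (0.22 log units; within the scatter). The estimate for compound 3 is 26000 nM, with an estimated range of 8000 nM to 85000 nM.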

Compound 3, half-maximal inhibitory concentration: 56300 nM
Estimate against measurement, compound 3: 2.2-fold (0.34 log units) below; measured number inside the range.
By their numbers in this assay, from the lowest: compounds 1 and 3 (each within the scatter of the next); then compound 2.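

In this assay phenyl in place of methoxy on this aromatic carbon gives a 1.3-fold higher number from compound 1 to compound 3 (0.11 log units; within the scatter) and so leaves the reading unchanged, even with a whole extra aromatic ring entering. The large step of a 13-fold higher number from compound 1 to compound 2 (1.13 log units; beyond the scatter) on losing the entire 4-methoxyphenyl therefore does not call for methoxy in particular, since phenyl serves equally here. Nothing available explains why these two groups read alike.

Still open, on these data alone, is whether a plain phenyl, with hydrogen on this carbon, keeps the reading. Also open, as far as these compounds go, is how an amine or a carboxylic acid would fare here.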